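Swapping thiophen-3-yl for thiophen-2-yl in compound 2

A few compounds are considered here, and "the series" means these few. Any claim that something is new, unique, unknown or untested is made for them only; others in the source may bear on it.

Compound 1 `Cc1cn2c(/C=N/Nc3ccccn3)c(-c3ccc(Cl)c([N+](=O)[O-])c3)nc2s1` gives 26300 nM
Compound 2 `Cc1cn2c(/C=N/NC(=N)N)c(-c3ccsc3)nc2s1` gives 5370 nM
Compound 3 `N=C(N)N/N=C/c1c(-c2ccsc2)nc2sccn12` gives 14100 nM

In a functional assay on cells (Cancer cell lines, Homo sapiens) for inhibition (on this read-out lower numbers stand for stronger inhibition of growth and higher numbers for weaker inhibition of growth), compound 2 holds the lowest number of the three, at 5370 nM and clearly apart from both others. The open question is compound 4 `Cc1cn2c(/C=N/NC(=N)N)c(-c3cccs3)nc2s1`, which has the same atoms as compound 2 joined differently, with thiophen-2-yl in place of thiophen-3-yl on an aromatic carbon. The counted difference reads: thiophen-2-yl in place of thiophen-3-yl on an aromatic carbon and nothing else in the structure changes.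

Within the data shown here, no measured pair makes this swap, so the data offer no direct precedent. Among the measured compounds shown here, the only measured step, a 2.6-fold higher number from compound 2 to compound 3 (0.42 log units; beyond the scatter), comes from a different change, hydrogen in place of methyl on an aromatic carbon, and it serves only as a rough gauge of how far a small edit can move this read-out. A shift smaller than that modest step is therefore expected, with no firm direction. The expected change is a 1.1-fold higher number from compound 2 to compound 4 (0.05 log units; within the scatter) and would probably stay within the scatter. In this assay the estimate for compound 4 is 6000 nM, with an expected range from 2500 nM to 15000 nM.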

Compound 4, concentration for 50% growth inhibition: 2570 nM
Beside the measured number, compound 4's estimate is 2.3-fold (0.37 log units) above it; the range from low to high includes it.
By their numbers in this assay, from the lowest: compound 4; then compound 2; then compounds 3 and 1 (each within the scatter of the next).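

In this assay, changing only how the thiophene is joined gives a 2.1-fold lower number from compound 2 to compound 4 (0.32 log units; beyond the scatter), so this aromatic carbon of the shared core is sensitive to the ring's attachment point, even though thiophen-2-yl and thiophen-3-yl have the same counted heavy atoms, hydrogen-bond acceptors and charge. The earlier compounds shown here offered only a 2.6-fold higher number from compound 2 to compound 3 (0.42 log units; beyond the scatter), which came from replacing methyl with hydrogen and said nothing about the group on this carbon. Nothing available here accounts for the difference between the two thiophene attachments.

The compounds shown leave open whether the same step would appear on the core without the methyl, as in compound 3. They also leave open how a furan-2-yl or cyclopropyl group on this carbon would compare with thiophen-2-yl.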